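The source may hold more compounds than are shown below. What is called first, only, known or untested is meant among the compounds shown, and "the series" means these compounds.

Working notes on the series built on the core of compound 1 `CC(=O)c1cc2cc(C)ccc2oc1=O`. Within the data shown here, in an in vitro assay on BTI-TN-5B1-4 cells for inhibition of Amine oxidase [flavin-containing] B (Homo sapiens), read by fluorescence, with a stated time of 15 min, tested at 100 uM (on this read-out lower numbers stand for less inhibition and higher numbers for more inhibition at the one concentration tested (going by the name of the read-out)), compound 1 gives 40% and stands as the only compound with a number. Compound 2 `CC(=O)c1cc2cc(I)cc(I)c2oc1=O` is reported in this assay as "not active" (no number reported), with no figure attached. Compound 3 `Cc1ccc2oc(=O)c(C(=O)c3ccccc3)cc2c1` has not yet been measured in this assay. Its difference from compound 1 is phenyl in place of methyl on a carbonyl carbon. Among the measured compounds shown here, no step between two measured compounds is available, so no size can be read across from the data. The step expected from this change is no change at the digits printed from compound 1 to compound 3 (within the scatter), none beyond the scatter. Compound 3 is accordingly estimated at 40%, with a range from 15% to 65%.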

Compound 3, a percentage reported as inhibition, at one concentration (the size of the read-out at that concentration, not a potency): 40%
Compound 3: middle estimate and measured number agree at the digits printed; low and high end bracket the measured number.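

Phenyl in place of methyl on a carbonyl carbon gives no change at the digits printed from compound 1 to compound 3 (within the scatter) in this assay, the first step in the series that can be read. At this place, a six-membered aromatic ring of carbon only can therefore stand in for a single methyl carbon with no difference beyond the scatter. Nothing available bears on why the read-out holds. Still open, from the compounds shown here alone, is whether an amine or a carboxylic acid on this carbonyl carbon would move the read-out, and whether the same swap reads alike with other substituents on the shared core.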